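The compounds below may be only part of what the source reports. "The series", "measured", "known", "first", "only" and "open" are said of these compounds alone.

In a functional assay on HeLa cells (Homo sapiens) for inhibition, with a stated time of 72 h (on this read-out lower numbers stand for an effect already at smaller amounts and higher numbers for an effect only at larger amounts of compound), compound 1 (`COc1cc(CNCc2ccncc2)ccc1OCc1ccc([N+](=O)[O-])cc1`) gives 440 nM while compound 2 (`COc1cc(CNCc2ccncc2)ccc1OCc1ccc(Cl)cc1`) gives 890 nM and compound 3 (`COc1cc(CNCc2ccncc2)ccc1OCc1cnc(Cl)c(Cl)c1`) gives 220 nM at the low end of the three numbers. Compound 4 (`COc1cc(CNCc2ccncc2)ccc1OCc1cccc(F)c1`) differs from compound 3 in one group (3-fluorophenyl in place of 5,6-dichloropyridin-3-yl on a saturated chain carbon bound to an oxygen on an aromatic ring) with 3-fluorophenyl in place of 5,6-dichloropyridin-3-yl. The closest guide is a 4.0-fold lower number from compound 2 to compound 3 (0.61 log units; beyond the scatter) on moving from 4-chlorophenyl to that same 5,6-dichloropyridin-3-yl, supported weakly by a 2.0-fold lower number from compound 1 to compound 3 (0.30 log units; within the scatter) from 4-nitrophenyl. Leaving 5,6-dichloropyridin-3-yl is therefore expected to raise the number by a modest step. The expected change is a 3.4-fold higher number from compound 3 to compound 4 (0.53 log units; beyond the scatter) in this assay by this estimate. Compound 4 is estimated at 750 nM with an expected range of 280 nM to 2000 nM in all.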

Compound 4, half-maximal effective concentration: 4800 nM
Estimate against measurement, compound 4: 6.4-fold (0.81 log units) below; the whole stated range lies below it.
By their numbers in this assay, from the lowest: compounds 3 and 1 (each within the scatter of the next); then compound 2; then compound 4.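

In this assay, 3-fluorophenyl on this saturated chain carbon bound to an oxygen on an aromatic ring gives the highest number of the four groups, with a rise of a 22-fold higher number from compound 3 to compound 4 (1.34 log units; beyond the scatter) and of an 11-fold higher number from compound 1 to compound 4 (1.04 log units; beyond the scatter) and of a 5.4-fold higher number from compound 2 to compound 4 (0.73 log units; beyond the scatter). For the compounds shown here, exchanging this group can therefore shift the number much further than the earlier compounds showed. No evidence given here accounts for the size of this rise. The compounds shown leave open where plain phenyl would fall. They also leave open whether pyridin-3-yl without chlorine would stay near compound 3 or move toward compound 4.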